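Replacing hydroxymethyl with carboxy on compound 3

A few compounds are considered here, and "the series" means these few. Any claim that something is new, unique, unknown or untested is made for them only; others in the source may bear on it.

Three related compounds have been measured: compound 1 `Cc1cc(=O)c2c(O)cc(OC/C=C/c3ccccc3)c([C@H]3CCN(C)C[C@H]3O)c2o1`, compound 2 `Cc1cc(=O)c2c(O)c(CN3CCN(C(=O)OC(C)(C)C)CC3)c(O)c([C@H]3CCN(C)C[C@H]3O)c2o1` and compound 3 `Cc1cc(=O)c2c(O)c(CN3CCCC3CO)c(O)c([C@H]3CCN(C)C[C@H]3O)c2o1`. In a functional assay on PC-3 cells (Homo sapiens) for inhibition, read by MTT assay, with a stated time of 48 h, tested at 10 uM (a higher number here means more inhibition of growth at the concentration tested, a lower number less inhibition of growth), compound 1 gives 18%, compound 2 gives 1% and compound 3 gives 15%. Compound 3 is level with compound 1 within the scatter and stands beyond the scatter above compound 2.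

Compound 4 `Cc1cc(=O)c2c(O)c(CN3CCCC3C(=O)O)c(O)c([C@H]3CCN(C)C[C@H]3O)c2o1` carries carboxy in place of hydroxymethyl on a saturated ring carbon. Within the data shown here, no measured pair shows this change, so the evidence is thin. Starting from compound 3 at 15%, a small downward step in this assay is expected, probably none beyond the scatter. The expected step is a number 7 percentage points lower from compound 3 to compound 4 (within the scatter). Compound 4 is estimated at 8%, with an expected range of 0% to 20%.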

Compound 4, percent growth inhibition at one concentration: 0%
Compound 4: the middle estimate sits 8 percentage points above what was measured, and the stated range covers the measured number.
By their numbers in this assay, from the lowest: compounds 4 and 2 (each within the scatter of the next); then compounds 3 and 1 (each within the scatter of the next).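

Among these compounds, putting carboxy in place of hydroxymethyl on this saturated ring carbon, next to the ring nitrogen, gives in this assay a number 15 percentage points lower from compound 3 to compound 4 (beyond the scatter) and is the first single change that can be read here. Growth inhibition therefore depends on the group at this carbon, which the earlier compounds, differing in more than one place, could not show. Nothing at hand explains the step.
On these data alone, whether a primary amide or a methyl ester at this carbon would behave like hydroxymethyl or like carboxy remains open, as does the effect of a longer chain ending in hydroxyl.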